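The source may report more compounds than this note shows. Statements on the series, on what has been measured and on what is new or still open speak of the compounds shown alone.

Compound 1, with the structure `CCCOC1=C(CCC)C(=O)/C(=C(O)/C=C/c2ccccc2)C(=O)C1(CCC)CCC`, is the more closely studied of the two measured compounds. In a functional assay on A549 cells (Homo sapiens) for antiproliferative activity, read by sulforhodamine B assay, with a stated time of 3 days (on this read-out higher numbers stand for an effect only at larger amounts of compound and lower numbers for an effect already at smaller amounts), compound 1 gives 1.9 uM, the lowest of the two numbers recorded. Among the compounds with values here, its only measured neighbour is compound 2, with the structure `CCCC1=C(OC)C(CCC)(CCC)C(=O)/C(=C(O)\C=C\c2ccccc2)C1=O`, which in this assay gives 3.6 uM; the step of a 1.9-fold higher number from compound 1 to compound 2 (0.28 log units; within the scatter) is within the scatter, so the two compounds cannot be told apart on this read-out.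

Compound 3, with the structure `CCCOC1=C(CCC)C(=O)/C(=C(O)/C=C/c2ccc(I)cc2)C(=O)C1(CCC)CCC`, differs from compound 1 in a single place: iodo in place of hydrogen on an aromatic carbon. Within the data shown here, none of the measured steps concerns this part of the molecule; the one step available changes a saturated chain instead. With no comparable change measured, no shift beyond the scatter is expected, and the step is estimated as no change at the digits printed from compound 1 to compound 3 (within the scatter). For compound 3 in this assay the expected value is therefore 1.9 uM, with a range from 0.7 uM to 5.5 uM.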

Compound 3, concentration for half-maximal effect: 8.2 uM
Compound 3: middle estimate off by 4.3-fold (0.64 log units), on the low side; measured number above the stated range.
By their numbers in this assay, from the lowest: compounds 1 and 2 (each within the scatter of the next); then compound 3.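

In this assay, the change from phenyl to 4-iodophenyl, on an aromatic carbon para to a large group, gives a 4.3-fold higher number from compound 1 to compound 3 (0.64 log units; beyond the scatter) and so counts as a real if modest loss of activity. Within the data shown here, this is the first sign that the number responds to a change at the aromatic end of compound 1, since the only earlier step, on a saturated chain, stayed within the scatter. Nothing available explains why the iodo group has this effect.

A single group at a single place cannot show whether the loss is specific to iodo or would also follow from fluoro, methoxy or an amine there. As far as these compounds go, whether iodo on another carbon of the same aromatic ring would give a similar number also stays open.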